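Bromo for chloro on the haloacetamido sugar series

The source may hold more compounds than are shown below. What is called first, only, known or untested is meant among the compounds shown, and "the series" means these compounds.

Two acylated amino-sugar haloacetamides have been measured. Compound 1 `CC(=O)OC[C@H]1O[C@@H](OC(C)=O)[C@H](NC(=O)CBr)[C@@H](OC(C)=O)[C@@H]1OC(C)=O` gives 3000 nM in a functional assay on cells (Leukemia cell, Mus musculus, strain DBA/2J) for antiproliferative activity, read by cell counting, with a stated time of 3 days; a lower number here means a stronger inhibitor, a higher number a weaker inhibitor. Compound 2 `CC(=O)OC[C@H]1O[C@@H](OC(C)=O)[C@H](NC(=O)CCl)[C@@H](OC(C)=O)[C@H]1OC(C)=O` gives 15000 nM in this assay, the higher of the two numbers; compound 1 sits at a value lower by a margin beyond the scatter. Within the data shown here, compound 1 and compound 2 differ in more than one place, so their pair alone does not isolate the halogen exchange, and no single-change step between measured compounds is available.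

Compound 3 `CC(=O)OC[C@H]1O[C@@H](OC(C)=O)[C@H](NC(=O)CBr)[C@@H](OC(C)=O)[C@H]1OC(C)=O` is not yet measured. Relative to compound 2 the change is bromo in place of chloro on a saturated chain carbon bound to a carbonyl carbon. Among the measured compounds shown here, the only guide is that the bromo-bearing compound 1 gives the lower of the two numbers, 3000 nM, while the chloro-bearing compound 2 gives 15000 nM; with the other differences between them unresolved, this guide is weak. A step toward a lower number is expected for compound 3, of moderate size, a 3.8-fold lower number from compound 2 to compound 3 (0.57 log units; beyond the scatter). Compound 3 is estimated at 4000 nM in this assay, with a range from 1500 nM to 12000 nM.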

Compound 3, half-maximal inhibitory concentration: 4000 nM
Compound 3: the middle estimate sits on the measured number at the digits printed, and the stated range covers the measured number.
By their numbers in this assay, from the lowest: compounds 1 and 3 (each within the scatter of the next); then compound 2.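

In this assay, the halogen exchange now stands alone: bromo in place of chloro on a saturated chain carbon bound to a carbonyl carbon gives a 3.8-fold lower number from compound 2 to compound 3 (0.57 log units; beyond the scatter), a step beyond the scatter with the rest of the structure unchanged. The second step, a 1.3-fold higher number from compound 1 to compound 3 (0.12 log units; within the scatter), shows that with bromo in place, the configuration at the one differing saturated ring carbon does not move the number beyond the scatter. Reading this second step as a purely stereochemical comparison rests on one fact: the fact that compounds 1 and 3 differ only in the configuration as drawn

Still open, on these data alone, is whether the configuration at that ring carbon is equally silent with chloro, since the stereochemical comparison stands on bromo alone and the halogen comparison on a single configuration. Also open, as far as these compounds go, is how far the series follows the group on the chain carbon, for example with iodo, with an amine in place of the halogen, or with a plain acetamide carrying no halogen, and whether either step survives on a core with free hydroxyl groups in place of the acetates.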